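Cyclopropyl for chloro on compound 1: expected cytotoxicity

The source may report more compounds than this note shows. Statements on the series, on what has been measured and on what is new or still open speak of the compounds shown alone.

Compound 1 `O=C(NCc1ccccc1)Nc1[nH]nc(-c2ccccn2)c1Cl` is tested in an ADME assay on cells (Peritoneal macrophage cell, Mus musculus) for cytotoxicity, read by fluorescence and resazurin assay, with a stated time of 3 days; on this read-out lower numbers stand for higher toxicity in this test and higher numbers for lower toxicity in this test; in this assay compound 1 gives > 64000 nM, which is a limit of the assay rather than a number. Compound 2 `O=C(Nc1cc(-c2ccccn2)n[nH]1)N1CCC(Oc2ccccn2)CC1` likewise gives only a limit in this assay, namely > 64000 nM. Compound 3 `O=C(Nc1cc(-c2ccccn2)n[nH]1)N1CCC(c2ccccc2)CC1` also sits at a limit in this assay, > 64000 nM. The step that the two limits leave unreadable from compound 2 to compound 3 cannot be read, since both of its ends are limits. All three values rest at the same limit (the limit of > 64000 nM in this assay, at which 3 of the 3 values shown sit). Compound 1 therefore stands among values that are all limits, with no number to place it against. Compound 4 `O=C(NCc1ccccc1)Nc1[nH]nc(-c2ccccn2)c1C1CC1` differs from compound 1 by cyclopropyl in place of chloro on an aromatic carbon. No measured step bears on this change; the only step shown, from compound 2 to compound 3, is unreadable and concerns a different part of the structure. Compound 4 is therefore expected to give 100000 nM in this assay, most likely again a limit, within 40000 nM to 300000 nM. The step that the limit leaves unreadable from compound 1 to compound 4 is expected to be none beyond the scatter.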

Compound 4, half-maximal cytotoxic concentration: > 45000 nM
Compound 4: no number, only a limit; the forecaster's own chance of this, stated with the estimate: 85%; the middle value is on the limit's open side.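

In this assay compound 4 gives > 45000 nM, a limit and not a number. Compound 1 also sits at a limit, > 64000 nM, so the step between these two compounds cannot be read. The compounds shown leave open whether cyclopropyl in place of chloro changes cytotoxicity at all.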